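A Trifluoromethoxy Swap in a Cytotoxicity-Silent Ester Series

The compounds below may be only part of what the source reports. "The series", "measured", "known", "first", "only" and "open" are said of these compounds alone.

Compound 3, `CCOC(=O)CCCCCOc1cccc(CN(C(=O)c2ccc(-c3cccc(-c4ccccc4)c3)cc2)C(C)C)c1`, was tested in an ADME assay on HepG2 cells (Homo sapiens) for cytotoxicity, read by CellTiter-Glo and resazurin assay, with a stated time of 72 h; on this read-out higher numbers stand for an effect only at larger amounts of compound and lower numbers for an effect already at smaller amounts. In this assay compound 3 gives > 26000 nM, which is a limit of the assay rather than a number. Its two measured relatives fare the same way. Compound 1, `CC(C)N(Cc1cccc(OCCCCCC(=O)O)c1)C(=O)c1ccc(-c2cccc(-c3ccccc3)c2)cc1`, gives > 26000 nM in this assay, again a limit. Compound 2, `CC(C)N(Cc1cccc(OCCCCCC(=O)O)c1)C(=O)c1ccc(-c2cccc(Cl)c2)cc1`, gives > 21900 nM in this assay, also a limit. Hence the step that the two limits leave unreadable from compound 1 to compound 2 and the step that the two limits leave unreadable from compound 1 to compound 3 cannot be sized; all that is known is the limit of > 21900 nM in this assay, at which 1 of the 3 values shown sits, and (the limit of > 26000 nM in this assay, at which 2 of the 3 values shown sit).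

Compound 4, `CCOC(=O)CCCCCOc1cccc(CN(C(=O)c2ccc(-c3cccc(OC(F)(F)F)c3)cc2)C(C)C)c1`, differs from compound 3 at one place: trifluoromethoxy in place of phenyl on an aromatic carbon. Read one bond further out, 3-phenylphenyl becomes 3-(trifluoromethoxy)phenyl. Among the compounds with values here, the only measured step that touches the same group is a step that the two limits leave unreadable from compound 1 to compound 2, in which phenyl also leaves an aromatic carbon, and it lies between two limits. Within the data shown here, since every value so far is a limit, the step that the limit leaves unreadable from compound 3 to compound 4 is estimated to stay within the scatter. Compound 4 is therefore expected to give about 30000 nM in this assay, within a range from 15000 nM to 60000 nM, most likely reported once more as a limit.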

Compound 4, half-maximal effective concentration: > 26000 nM
Compound 4: a limit, no number; the forecaster's own chance of this, stated with the estimate: 85%; the middle value lies beyond the limit too.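

In this assay both compound 3 and compound 4 stand only at limits of the assay, so no size can be read for the step between them. The compounds shown leave open at what concentration, if any, compound 1, compound 2, compound 3 or compound 4 would affect these cells, and whether trifluoromethoxy in place of phenyl changes that.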